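The source may report more compounds than this note shows. Statements on the series, on what has been measured and on what is new or still open speak of the compounds shown alone.

Compounds measured so far in a functional assay for inhibition, with Homo sapiens as the target; on this read-out lower numbers stand for tighter binding and higher numbers for weaker binding:
- compound 1 `O=C(O)CC/C=C\CC1COC(c2cccc3ccccc23)OC1c1cccnc1` gives 631 nM
- compound 2 `CC(C)(C)c1ccc(OC(C)(C)C2OCC(C/C=C\CCC(=O)O)C(c3cccnc3)O2)cc1` gives 1910 nM

Compound 2 has the highest number of the two, and the gap to compound 1 is beyond the usual scatter, so compound 2 is the weaker binder of this pair.

Compound 3 `CC(C)(C1OCC(C/C=C\CCC(=O)O)C(c2cccnc2)O1)S(=O)(=O)c1ccccc1` is the next compound. It differs from compound 2 in one place: phenylsulfonyl in place of 4-(tert-butyl)phenoxy on a saturated chain carbon bound to two saturated chain carbons and a saturated ring carbon. Within the data shown here, no step between two measured compounds involves this kind of change, so there is no measured precedent to lean on; the two known values only set the scale of this series. On that basis a modest step in this assay is expected, and its direction is uncertain.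

Compound 3 is expected to give 1500 nM, with a likely range from 400 nM to 6000 nM. The estimated step of a 1.3-fold lower number from compound 2 to compound 3 (0.10 log units; within the scatter) would remain within the usual scatter.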

Compound 3, dissociation constant: 3160 nM
Compound 3: middle estimate off by 2.1-fold (0.32 log units), on the low side; low and high end bracket the measured number.
By their numbers in this assay, from the lowest: compound 1; then compounds 2 and 3 (each within the scatter of the next).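

In this assay, putting phenylsulfonyl in place of 4-(tert-butyl)phenoxy on this saturated chain carbon gives a 1.7-fold higher number from compound 2 to compound 3 (0.22 log units; within the scatter), so the read-out does not separate these two compounds. Among these compounds, this is the first step that can be read at this position. The two groups share one six-membered aromatic ring of carbon only but differ in heavy atoms and in hydrogen-bond acceptors, and here those differences come with no step beyond the scatter. No measurement shown explains this result.

The compounds shown leave open how this position responds to a group without an aromatic ring, such as an amine or a plain methyl group. They also do not show how a sulfonamide in the same place would read.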